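The source may report more compounds than this note shows. Statements on the series, on what has been measured and on what is new or still open speak of the compounds shown alone.

Measured so far in a functional assay on HepG2 cells (Homo sapiens) for antiproliferative activity; on this read-out lower numbers stand for stronger inhibition and higher numbers for weaker inhibition:
Compound 1 `CC[C@H](C)[C@H]1C(=O)N[C@H](Cc2cc(Cl)c(O)c(Cl)c2)C(=O)N[C@@H](C(C)C)C(=O)O[C@H](c2ccccc2)[C@H](C)/C=C/C=C(\C)[C@H](OC)C[C@@H]2O[C@@]2(C)C(=O)N1C` gives 5.65 nM here
Compound 2 `CC[C@H](C)[C@H]1C(=O)N[C@H](Cc2cc(Cl)c(O)c(Cl)c2)C(=O)N[C@@H](C(C)C)C(=O)O[C@H](c2ccccc2)[C@H](C)/C=C/C=C(\C)[C@H](OC)C/C=C(\C)C(=O)N1C` gives 104 nM here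

Compound 1 holds the lower of these two numbers, and thus the stronger inhibition, and its gap to compound 2 lies beyond the usual scatter of repeated measurements. Compound 3 `CC[C@H](C)[C@H]1C(=O)N[C@H](Cc2ccc(O)c(Br)c2)C(=O)N[C@@H](C(C)C)C(=O)O[C@H](c2ccccc2)[C@H](C)/C=C/C=C(\C)[C@H](OC)C[C@@H]2O[C@@]2(C)C(=O)N1C` has not yet been measured. It keeps the core of compound 1 and differs from it as follows: 3-bromo-4-hydroxyphenyl in place of 3,5-dichloro-4-hydroxyphenyl on a saturated chain carbon bound to a saturated ring carbon in all. Going by the values given here, no measured step covers this change, so the expectation rests on the structural change alone and remains uncertain. A moderate move toward weaker inhibition in this assay is expected, an estimated 2.7-fold higher number from compound 1 to compound 3 (0.42 log units; beyond the scatter) in size, and it may not clear the scatter by much. The estimated value for compound 3 is 15 nM as the middle, with an expected range from 4 nM to 60 nM around it.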

Compound 3, half-maximal inhibitory concentration: 6.84 nM
The estimate for compound 3 lay 2.2-fold (0.34 log units) above the measured number, within the range that was stated.
By their numbers in this assay, from the lowest: compounds 1 and 3 (each within the scatter of the next); then compound 2.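

In this assay, the step at this position, a 1.2-fold higher number from compound 1 to compound 3 (0.08 log units; within the scatter), lies within the scatter, so 3-bromo-4-hydroxyphenyl and 3,5-dichloro-4-hydroxyphenyl on a saturated chain carbon bound to a saturated ring carbon cannot be told apart on this read-out. Going by these compounds alone, with the core of compound 1 held constant, a single bromine in place of two chlorines therefore leaves no measurable mark in this assay, which is the first information about this group, as the earlier compounds differed elsewhere. Nothing available accounts for this outcome.

The compounds shown leave open how a methoxy group in place of the hydroxyl, or an amine on the phenyl ring, would read at this position. As far as these compounds go, it also remains open whether the same exchange of groups would read alike on compound 2.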